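Naphthalen-1-yl in place of 3,5-difluorophenyl on compound 3

The source may hold more compounds than are shown below. What is called first, only, known or untested is meant among the compounds shown, and "the series" means these compounds.

The account covers three measured compounds and one not yet measured, all tested in an assay on isolated protein (Bos taurus) for inhibition of geranylgeranyl transferase type-1 subunit beta (Homo sapiens); a higher number here means a weaker inhibitor, a lower number a stronger inhibitor. Compound 1 `Cn1cncc1C(OCc1nc(N2CCC(O)CC2)c(C#N)cc1-c1cccc(Cl)c1)c1ccc(C#N)cc1` gives 830 nM in this assay. Compound 2 `Cn1cncc1C(OCc1ccc(C#N)nc1-c1cccc(Cl)c1)c1ccc(C#N)cc1` gives 1700 nM in this assay. For compound 3 `Cn1cncc1C(OCc1ccc(C#N)cc1-c1cc(F)cc(F)c1)c1ccc(C#N)nc1` this assay reports only a limit, > 10 nM, so compound 3 cannot be placed among the numbers of the others; it simply sits at the limit described by the limit of > 10 nM in this assay, at which 1 of the 3 values shown sits. No pair of these compounds differs in one place, so no measured step can be drawn between them.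

Compound 4 `Cn1cncc1C(OCc1ccc(C#N)cc1-c1cccc2ccccc12)c1ccc(C#N)nc1` is the untested member. It differs from compound 3 by naphthalen-1-yl in place of 3,5-difluorophenyl on an aromatic carbon. Within the data shown here, since compound 3 is known only as a limit and no measured step is available, the size of the expected step in this assay cannot be anchored; the writer expects a change that may lie within the scatter or somewhat beyond it, with no firm direction. On that basis the estimated step that the limit leaves unreadable from compound 3 to compound 4 is given as an expectation only, and compound 4 is expected to give about 500 nM, between 50 nM and 5000 nM.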

Compound 4, half-maximal inhibitory concentration: > 10 nM
Compound 4 was reported as a limit; the forecaster's own chance of this, stated with the estimate: 25%; the middle value lies beyond the limit too.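

Compound 3 and compound 4 are both reported in this assay only as limits, so no step can be read between them: the limit of > 10 nM in this assay, at which 2 of the 4 values shown sit.

The compounds shown leave open whether naphthalen-1-yl in place of 3,5-difluorophenyl changes inhibition in this assay at all, and in which direction.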